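The source may hold more compounds than are shown below. What is called first, only, known or untested is meant among the compounds shown, and "the series" means these compounds.

Compound 1 `CN(C(=O)CNC(=O)CN)c1ccc([N+](=O)[O-])cc1C(=O)c1ccccc1Cl`: 10 mg/kg
Compound 2 `NCC(=O)NCC(=O)Nc1ccc([N+](=O)[O-])cc1C(=O)c1ccccc1`: 24.8 mg/kg

In a functional assay on the whole organism with Mus musculus as the target, in the rotarod test (a higher number here means that more compound is needed for the effect, a lower number that less compound is needed), compound 2 has the higher of the two numbers at 24.8 mg/kg, so more of it is needed for the effect. Compound 1 gives 10 mg/kg, and this gap lies beyond the usual scatter of the measurement.

The next compound is compound 3 `CN(C(=O)CNC(=O)CN)c1ccc([N+](=O)[O-])cc1C(=O)c1ccccc1`, which differs from compound 2 in a single place: methyl in place of hydrogen on an amide-type nitrogen, with methyl in place of hydrogen on an amide-type nitrogen. For the measured compounds named here, no pair of measured compounds shows this change on its own, so the data give no direct measure of its size. With so little to go on, the expectation is a modest shift towards the lower number of compound 1 at 10 mg/kg, and that shift may not clear the scatter. The expected change is a 1.7-fold lower number from compound 2 to compound 3 (0.22 log units; within the scatter), a small fall in the number rather than a large one. For compound 3 the estimate is 15 mg/kg, with an expected range from 7 mg/kg to 30 mg/kg.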

Compound 3, dose for half-maximal effect: 2.94 mg/kg
Beside the measured number, compound 3's estimate is 5.1-fold (0.71 log units) above it, outside the stated range (below it).
By their numbers in this assay, from the lowest: compound 3; then compound 1; then compound 2.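

In this assay, for the compounds shown here, methyl in place of hydrogen on an amide-type nitrogen gives an 8.4-fold lower number from compound 2 to compound 3 (0.93 log units; beyond the scatter) and so provides the first direct reading of this change on its own, showing that one added carbon at this position can shift the dose beyond the scatter. Going by these compounds alone, the other pair isolates a second change for the first time: hydrogen in place of chloro on an aromatic carbon gives a 3.4-fold lower number from compound 1 to compound 3 (0.53 log units; beyond the scatter) in compounds that both carry the methyl, so less compound is needed without the chloro group. Nothing measured here bears on why either step occurs.

From the compounds shown here alone, it remains open whether an ethyl group or a longer chain on the same amide-type nitrogen would continue this trend or reverse it, and whether fluoro or methoxy on that aromatic carbon would read more like hydrogen or like chloro. Going by these compounds, the size of the methyl step with chloro present also remains open, since that would need a chloro compound with hydrogen on the nitrogen.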